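Series notes: reduced 2-chlorobenzyl analogue following compound 2

The source may report more compounds than this note shows. Statements on the series, on what has been measured and on what is new or still open speak of the compounds shown alone.

Compound 2 `CCCCCCCCCCCCCCNC(=O)[C@H](CO)/N=C/c1ccccc1O` gives 19000 nM in a functional assay on cells (Homo sapiens) for cytotoxicity, read by MTT assay, with a stated time of 24 h; on this read-out lower numbers stand for stronger inhibition and higher numbers for weaker inhibition. Among the three measured numbers it stands second highest, with compound 1 nearest and compound 3 furthest. Compound 1 `CCCCCCCCCCCCCCNC(=O)[C@H](CO)/N=C/c1ccccc1Cl` gives 10300 nM in this assay, and a 1.8-fold higher number from compound 1 to compound 2 (0.27 log units; within the scatter). Compound 3 `CCCCCCCCCCCCCCNC(=O)[C@H](CO)/N=C/c1ccc([N+](=O)[O-])cc1` gives 217000 nM in this assay; an 11-fold higher number from compound 2 to compound 3 (1.06 log units; beyond the scatter), and a 21-fold higher number from compound 1 to compound 3 (1.32 log units; beyond the scatter).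

Compound 4 `CCCCCCCCCCCCCCNC(=O)[C@H](CO)NCc1ccccc1Cl` has not been measured. Against compound 2 the change is a group of 9 heavy atoms (7 carbon, 1 nitrogen, 1 chlorine; one six-membered aromatic ring of carbon only) in place of a group of 9 heavy atoms (7 carbon, 1 nitrogen, 1 oxygen; one six-membered aromatic ring of carbon only), on a saturated chain carbon bound to a carbonyl carbon and a saturated chain carbon. The chloro of compound 1 returns, and the double bond outside aromatic rings is gone. Of the measured steps only a 1.8-fold higher number from compound 1 to compound 2 (0.27 log units; within the scatter) bears on this change, and it lay within the scatter. Among the measured compounds shown here, no measured pair shows what loss of the double bond outside aromatic rings does in this assay, so that part of the change carries no expectation of its own and widens the range. For compound 4 the expected number in this assay is therefore close to compound 2 and compound 1, with no step beyond the scatter in either direction. The estimate for compound 4 is 12000 nM, within 3000 nM to 50000 nM. The step this estimate means is a 1.6-fold lower number from compound 2 to compound 4 (0.20 log units; within the scatter), expected to stay within the scatter.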

Compound 4, half-maximal inhibitory concentration: 43700 nM
Estimate against measurement, compound 4: 3.6-fold (0.56 log units) below; the measured number falls inside the stated range.
By their numbers in this assay, from the lowest: compounds 1 and 2 (each within the scatter of the next); then compound 4; then compound 3.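

In this assay, among the compounds shown here, the step of a 4.2-fold higher number from compound 1 to compound 4 (0.63 log units; beyond the scatter) is the first measured read on loss of the double bond outside aromatic rings with the chloro held in place, and it points to weaker inhibition once the (2-chlorobenzyl)amino group stands on the saturated chain carbon. The step of a 2.3-fold higher number from compound 2 to compound 4 (0.36 log units; beyond the scatter) points the same way, but it joins that loss to the return of the chloro, and the chloro-to-hydroxy exchange alone read only as a 1.8-fold higher number from compound 1 to compound 2 (0.27 log units; within the scatter) in the double-bonded pair. The measured steps therefore place the change in cytotoxicity read-out on the reduced linkage rather than on the ring substituent, while nothing available explains why this linkage gives the higher number.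

Whether the same shift holds for other rings remains open, since the (2-hydroxybenzyl)amino and (4-nitrobenzyl)amino counterparts of compound 2 and compound 3 do not appear among the compounds shown. Also open, from the compounds shown here alone, is whether an N-methyl group on the reduced amine, or a carboxylic acid in place of the hydroxymethyl group, would move the number in either direction.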